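Cyclobutyl to cyclopentyl on the shared core

The compounds below may be only part of what the source reports. "The series", "measured", "known", "first", "only" and "open" are said of these compounds alone.

In an ADME assay on Vero cells (Chlorocebus sabaeus) for cytotoxicity, read by CellTiter-Glo, with a stated time of 72 h (on this read-out higher numbers stand for lower toxicity in this test and lower numbers for higher toxicity in this test), compound 1 `CCNc1n[n+]([O-])c2cc(F)ccc2[n+]1[O-]` gives 4.6 ug/mL and compound 2 `[O-][n+]1nc(NC2CCC2)[n+]([O-])c2ccc(F)cc21` gives 1.6 ug/mL as the lower of the two numbers. Compound 3 `[O-][n+]1nc(NC2CCCC2)[n+]([O-])c2ccc(F)cc21` carries cyclopentyl in place of cyclobutyl on a nitrogen on an aromatic ring, with cyclopentyl in place of cyclobutyl on a nitrogen on an aromatic ring as the counted difference. Within the data shown here, the one measured step bearing on this is a 2.9-fold lower number from compound 1 to compound 2 (0.46 log units; beyond the scatter) for cyclobutyl in place of ethyl, modest and beyond the scatter. A small further drop in this assay is expected, possibly within the scatter, and a 1.3-fold lower number from compound 2 to compound 3 (0.12 log units; within the scatter) is the expected step. Compound 3 is estimated at 1.2 ug/mL with 0.5 ug/mL to 3 ug/mL as the expected range.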

Compound 3, half-maximal cytotoxic concentration: 2.3 ug/mL
For compound 3 the middle estimate is 1.9-fold (0.28 log units) below the measured one; measured number inside the range.
By their numbers in this assay, from the lowest: compounds 2, 3 and 1 (each within the scatter of the next, the first and the last beyond it).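

On the nitrogen on an aromatic ring, cyclopentyl in place of cyclobutyl gives a 1.4-fold higher number from compound 2 to compound 3 (0.16 log units; within the scatter), so this assay does not separate these two rings at this position. Cyclopentyl in place of ethyl gives a 2.0-fold lower number from compound 1 to compound 3 (0.30 log units; within the scatter), so compound 3 does not separate from either neighbour, although the ethyl and cyclobutyl pair stands beyond the scatter. No supporting data bear on a cause for these numbers.

On these data alone, whether a cyclohexyl ring or an isopropyl group on the same nitrogen would stay within this span remains open.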